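Extending the chain from compound 2 to compound 3

The source may hold more compounds than are shown below. What is called first, only, known or untested is meant among the compounds shown, and "the series" means these compounds.

compound 1 `CCCCCc1ccc(-c2c(C)[nH]c(=O)n2C2CCCCC2)cc1`: 10600 nM
compound 2 `CCCCCCCc1ccc(-c2c(C)[nH]c(=O)n2C2CCCCC2)cc1`: 8700 nM

Both compounds were tested in a functional assay on brain (Rattus norvegicus, strain Wistar) for inhibition (a lower number here means a stronger inhibitor, a higher number a weaker inhibitor), where compound 2 stands level with compound 1, within the scatter. Compound 3 `CCCCCCCCCCc1ccc(-c2c(C)[nH]c(=O)n2C2CCCCC2)cc1` keeps the shared core and differs only in its chain: propyl in place of hydrogen on a saturated chain carbon, seven bonds along the chain from an aromatic carbon. Going by the values given here, the one measured step that bears on this is the earlier chain extension, a 1.2-fold lower number from compound 1 to compound 2 (0.09 log units; within the scatter), and it stayed within the scatter. As far as these compounds go, no step beyond the scatter is therefore expected, although this extension is larger and remains untested. The estimated change is a 1.2-fold lower number from compound 2 to compound 3 (0.09 log units; within the scatter). The estimate for compound 3 is 7000 nM, with an expected range from 2500 nM to 19000 nM.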

Compound 3, half-maximal inhibitory concentration: 27000 nM
For compound 3 the middle estimate is 3.9-fold (0.59 log units) below the measured one; measured number above the stated range.
By their numbers in this assay, from the lowest: compounds 2 and 1 (each within the scatter of the next); then compound 3.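

In this assay the chain at this position no longer extends without consequence: propyl in place of hydrogen, seven bonds along the chain from an aromatic carbon, gives a weaker inhibitor (a 3.1-fold higher number from compound 2 to compound 3 (0.49 log units; beyond the scatter)), whereas the earlier extension stayed within the scatter. The longer extension from the shorter chain also goes beyond the scatter (a 2.5-fold higher number from compound 1 to compound 3 (0.41 log units; beyond the scatter)). Nothing available here accounts for this loss.

The compounds shown leave open whether a longer chain still would weaken inhibition further, and whether an amine or a carboxylic acid on the chain would change the outcome.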